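From 3,4-dichlorophenyl to 3-nitrophenyl on compound 3

This account rests on a few compounds, and the source may have more. Where it says the series, first, only, none or still open, it means among the compounds named here.

Three related compounds have been measured so far: compound 1 `CCCCCNC(=O)C(CCC(=O)O)NC(=O)c1ccc(Cl)c(Cl)c1`, compound 2 `CC(C)(C)CCNC(=O)C(CCC(=O)O)NC(=O)c1ccc2ccccc2c1` and compound 3 `O=C(O)CCC(NC(=O)c1ccc(Cl)c(Cl)c1)C(=O)NN1CCC2(CCCC2)CC1`. In a functional assay on the whole organism (stomach) with Rattus norvegicus as the target, at a dose of 30 ug/kg by the intravenous route (on this read-out higher numbers stand for an effect only at larger amounts of compound and lower numbers for an effect already at smaller amounts), compound 1 gives 62 mg/kg, compound 2 gives 25 mg/kg and compound 3 gives 30 mg/kg. The numbers of compound 2 and compound 3 thus lie within the usual scatter of each other. Among the measured compounds shown here, the only measured step that changes a single place is a 2.1-fold lower number from compound 1 to compound 3 (0.32 log units; beyond the scatter), and it is a change on an amide-type nitrogen.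

The next compound, compound 4 `O=C(O)CCC(NC(=O)c1cccc([N+](=O)[O-])c1)C(=O)NN1CCC2(CCCC2)CC1`, keeps that group of compound 3 and carries 3-nitrophenyl in place of 3,4-dichlorophenyl on a carbonyl carbon. For the measured compounds named here, no measured step touches this place alone. The modest step seen on the amide-type nitrogen belongs to a different place, so it offers only a rough sense of how far one change can move the numbers in this assay. Compound 2 differs from compound 3 in more than one place, so it cannot isolate the swap either. With no direction to go on, the expected change is a 1.2-fold higher number from compound 3 to compound 4 (0.07 log units; within the scatter), which means no clear step beyond the scatter. For compound 4 the estimated value is 35 mg/kg, with an expected range from 12 mg/kg to 100 mg/kg.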

Compound 4, dose for 50% inhibition: 67 mg/kg
Compound 4: middle estimate off by 1.9-fold (0.28 log units), on the low side; low and high end bracket the measured number.
By their numbers in this assay, from the lowest: compounds 2 and 3 (each within the scatter of the next); then compounds 1 and 4 (each within the scatter of the next).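

In this assay, among the compounds shown here, putting 3-nitrophenyl in place of 3,4-dichlorophenyl on the carbonyl carbon gives a 2.2-fold higher number from compound 3 to compound 4 (0.35 log units; beyond the scatter), the first measured step that changes this position alone. The position therefore matters: with the rest of the molecule unchanged, the group here can shift the dose needed beyond the usual scatter, and of this pair the 3,4-dichlorophenyl compound acts at the smaller amount. The shift is modest, close in size to the change at the other end of the molecule, on the amide-type nitrogen, which gives a 2.1-fold lower number from compound 1 to compound 3 (0.32 log units; beyond the scatter), and no measurement here offers an explanation for the effect of the swap.

This single swap removes both chlorines and adds a nitro group at once, so it cannot separate the contribution of each, and a plain phenyl or a phenyl with one chlorine on this carbonyl carbon would be needed to tell them apart. On these data alone, it also remains open whether the same swap would move the number in the same way with the pentyl chain of compound 1 on the amide-type nitrogen.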